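The compounds below may be only part of what the source reports. "The series", "measured", "known", "first", "only" and "open" are said of these compounds alone.

In an ADME assay on HEK-293T cells (Homo sapiens) for cytotoxicity, read by CCK-8 assay, with a stated time of 48 h (a lower number here means a stronger inhibitor, a higher number a weaker inhibitor), compound 1 `O=C(NCCNS(=O)(=O)c1ccc(-c2ccccc2Oc2ccc(O)c(O)c2)s1)Nc1cc(Cl)cc(Cl)c1` gives 12400 nM. Compound 2 `O=C(NCCNS(=O)(=O)c1ccc(-c2ccccc2O[C@H]2CC[C@H](O)CC2)s1)Nc1cc(Cl)cc(Cl)c1` reaches only a limit of this assay, > 50000 nM. Compound 3 `O=C(NCCNS(=O)(=O)c1ccc(-c2ccccc2Oc2ccc([N+](=O)[O-])c([N+](=O)[O-])c2)s1)Nc1cc(Cl)cc(Cl)c1` likewise reaches only a limit, > 20000 nM. The steps read an at least 4.0-fold higher number from compound 1 to compound 2 (0.60 log units; beyond the scatter) and an at least 1.6-fold higher number from compound 1 to compound 3 (0.20 log units; that floor lies within the scatter), while a step that the two limits leave unreadable from compound 2 to compound 3. Compound 2 thus stands only as a limit among these three numbers, and one further value is also a limit. Compound 4 `O=[N+]([O-])c1ccc(NC(=S)NCCNS(=O)(=O)c2ccc(-c3ccccc3O[C@H]3CC[C@H](O)CC3)s2)cc1` differs from compound 2 at a different place: a group of 12 heavy atoms (7 carbon, 2 nitrogen, 2 oxygen, 1 sulfur; one six-membered aromatic ring of carbon only) in place of a group of 11 heavy atoms (7 carbon, 1 nitrogen, 1 oxygen, 2 chlorine; one six-membered aromatic ring of carbon only), on an amine nitrogen. All measured steps concern the group on an oxygen on an aromatic ring, so none bears directly on this change, and compound 2 itself offers only a limit as the starting point. No step beyond the scatter is expected, a step that the limit leaves unreadable from compound 2 to compound 4. Compound 4 is estimated at 60000 nM, between 20000 nM and 200000 nM, most likely reported again as a limit.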

Compound 4, half-maximal inhibitory concentration: 10500 nM
For compound 4 the middle estimate is 5.7-fold (0.76 log units) above the measured one; the whole stated range lies above it.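

In this assay the change on the amine nitrogen gives an at least 4.7-fold lower number from compound 2 to compound 4 (0.67 log units; beyond the scatter) and so shows that this place, and not only the group on the oxygen on an aromatic ring, bears on the read-out. Compound 2 stands only at a limit, so the full size of the step stays unread: the limit of > 50000 nM in this assay, at which 1 of the 4 values shown sits.

The change swaps chlorine, oxygen and nitrogen content in one move, so the compounds shown do not separate the sulfur from the ring substituents. From the compounds shown here alone, whether a methoxy or trifluoromethyl group on that aromatic ring would give a similar step stays open.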